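This account rests on a few compounds, and the source may have more. Where it says the series, first, only, none or still open, it means among the compounds named here.

compound 1 `Cc1ccc(NC(=O)c2cc3ccccc3oc2=O)cc1`: 710 nM
compound 2 `CCc1ccc(NC(=O)c2cc3ccccc3oc2=O)cc1`: 890 nM
compound 3 `CC(C)c1ccc(NC(=O)c2cc3ccccc3oc2=O)cc1`: 650 nM

All three share one core and differ only in the group on the aromatic ring. In an in vitro assay on BTI-TN-5B1-4 cells for inhibition of Amine oxidase [flavin-containing] B (Homo sapiens), read by fluorescence (on this read-out lower numbers stand for stronger inhibition and higher numbers for weaker inhibition), compound 3 gives the lowest of the three numbers, though its steps to the others, a 1.1-fold lower number from compound 1 to compound 3 (0.04 log units; within the scatter) and a 1.4-fold lower number from compound 2 to compound 3 (0.14 log units; within the scatter), both lie within the scatter. Compound 4 `COc1ccc(NC(=O)c2cc3ccccc3oc2=O)cc1` differs from compound 3 by methoxy in place of isopropyl on an aromatic carbon. Going by the values given here, the measured steps, a 1.3-fold higher number from compound 1 to compound 2 (0.10 log units; within the scatter) included, all concern exchanges among alkyl groups at this place and none moved the number beyond the scatter; none of them brings in a methoxy, so that part of the change has no counterpart in the data. With nothing pointing either way, compound 4 is expected to show a 1.1-fold higher number from compound 3 to compound 4 (0.03 log units; within the scatter), a step within the scatter. Compound 4 is estimated at 700 nM, between 300 nM and 1800 nM.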

Compound 4, half-maximal inhibitory concentration: 820 nM
Compound 4: middle estimate off by 1.2-fold (0.07 log units), on the low side; the measured number falls inside the stated range.
By their numbers in this assay, from the lowest: compounds 3, 1, 4 and 2 (each within the scatter of the next).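

Methoxy is the first group at this place on the aromatic ring to bring in an oxygen and a hydrogen-bond acceptor, yet in this assay the number barely responds: a 1.3-fold higher number from compound 3 to compound 4 (0.10 log units; within the scatter) and a 1.1-fold lower number from compound 2 to compound 4 (0.04 log units; within the scatter) and a 1.2-fold higher number from compound 1 to compound 4 (0.06 log units; within the scatter) all lie within the scatter. Replacing an alkyl group with methoxy therefore behaves like the exchanges among alkyl groups, with no step beyond the scatter. Nothing available explains this result. Still open, on these data alone, is whether an amine, a carboxylic acid or a longer chain here would move the number beyond the scatter.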